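The compounds below may be only part of what the source reports. "The series", "measured", "known", "first", "only" and "open" are said of these compounds alone.

Measured compounds in an in vitro ADME assay on microsomes from liver (Rattus norvegicus) for metabolic stability, read by LC-MS, tested at 1 uM; a lower number here means slower removal, a higher number faster removal of the compound:
Compound 1, `COCCN(C)S(=O)(=O)c1ccc(C)c(C#Cc2cc(Cl)ccc2OCC(=O)O)c1`, gives 49 mL.min-1.g-1.
Compound 2, `Cc1ccc(S(=O)(=O)N(C)CC(C)C)cc1C#Cc1cc(Cl)ccc1OCC(=O)O`, gives 119 mL.min-1.g-1.
Compound 3, `Cc1ccc(S(=O)(=O)N(C)C)cc1C#Cc1cc(Cl)ccc1OCC(=O)O`, gives 22 mL.min-1.g-1.

Compound 3 shows the lowest number of the three in this assay; compound 1 stands nearest to it and compound 2 furthest, both beyond the scatter. Compound 4, `Cc1ccc(S(=O)(=O)N2CCOCC2)cc1C#Cc1cc(Cl)ccc1OCC(=O)O`, is not yet measured. It differs from compound 3 in one place: morpholin-4-yl in place of dimethylamino on a sulfonyl sulfur. Among the compounds with values here, two measured steps bear on this change, since both also alter what sits on the sulfonamide nitrogen. Here a 5.4-fold lower number from compound 2 to compound 3 (0.73 log units; beyond the scatter), and a 2.2-fold lower number from compound 1 to compound 3 (0.35 log units; beyond the scatter). Read the other way, putting an isopropyl or a methoxymethyl onto the nitrogen substituent raised the number, and the larger addition raised it more. Within the data shown here, the morpholin-4-yl likewise brings more heavy atoms and a ring to this nitrogen, though none of the measured steps shows a ring closing there, so the size of the effect is uncertain. A modest rise for compound 4 in this assay is expected because a 5.4-fold lower number from compound 2 to compound 3 (0.73 log units; beyond the scatter) and a 2.2-fold lower number from compound 1 to compound 3 (0.35 log units; beyond the scatter) both show that a smaller nitrogen substituent went with a lower number. Compound 4 is therefore estimated at 35 mL.min-1.g-1, within a range from 15 mL.min-1.g-1 to 80 mL.min-1.g-1. The step this estimate implies is a 1.6-fold higher number from compound 3 to compound 4 (0.20 log units; within the scatter).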

Compound 4, intrinsic clearance in microsomes: 10 mL.min-1.g-1
Beside the measured number, compound 4's estimate is 3.5-fold (0.54 log units) above it, and the stated range ends above it.
By their numbers in this assay, from the lowest: compound 4; then compound 3; then compound 1; then compound 2.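

In this assay, morpholin-4-yl on the sulfonyl sulfur carries more heavy atoms than dimethylamino, yet the number falls (a 2.2-fold lower number from compound 3 to compound 4 (0.34 log units; beyond the scatter)), so size alone does not set the number at this position. The drop is larger against the two open-chain groups, isobutyl(methyl)amino (a 12-fold lower number from compound 2 to compound 4 (1.08 log units; beyond the scatter)) and (2-methoxyethyl)(methyl)amino (a 4.9-fold lower number from compound 1 to compound 4 (0.69 log units; beyond the scatter)). Larger groups went with higher numbers across compound 1, compound 2 and compound 3, but compound 4 goes against that pattern, which shows that the kind of group matters as well as its size.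

Going by these compounds, whether the ring or its oxygen matters more stays open; piperidin-1-yl, the same six-membered ring with carbon in place of that oxygen, would help separate the two. No evidence shown here explains the lower number.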